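This account rests on a few compounds, and the source may have more. Where it says the series, first, only, none or still open, it means among the compounds named here.

Measured in a functional assay on DU-145 cells (Homo sapiens) for inhibition, read by sulforhodamine B assay, with a stated time of 48 h; on this read-out higher numbers stand for weaker inhibition of growth and lower numbers for stronger inhibition of growth:
compound 1 `Cc1ccc(C2=NN(c3ccc(S(C)(=O)=O)cc3)C(=O)CC2)cc1`: 2910 nM
compound 2 `Cc1cc(O)ccc1C1=NN(c2ccc(S(C)(=O)=O)cc2)C(=O)CC1`: 24700 nM

Compound 2 has the higher of the two numbers, which makes it the weaker growth inhibitor of this pair. The next compound is compound 3 `CCc1ccc(C2=NN(c3ccc(S(C)(=O)=O)cc3)C(=O)CC2)cc1`, with this change from compound 2: 4-ethylphenyl in place of 4-hydroxy-2-methylphenyl on a carbon with a double bond to nitrogen. 4-Ethylphenyl stands in place of 4-hydroxy-2-methylphenyl on a carbon with a double bond to nitrogen.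

Among the compounds with values here, only one measured step bears on this: an 8.5-fold higher number from compound 1 to compound 2 (0.93 log units; beyond the scatter), where 4-hydroxy-2-methylphenyl replaced 4-methylphenyl on that same carbon. That step is modest but beyond the scatter. Compound 3 no longer carries 4-hydroxy-2-methylphenyl, so a change of similar size in the opposite direction is expected, towards a lower number in this assay. Within the data shown here, no measured step covers 4-ethylphenyl itself, so the range stays wide and the expectation rests on compound 1 at 2910 nM.

The expected step is a 7.1-fold lower number from compound 2 to compound 3 (0.85 log units; beyond the scatter).

Compound 3 is estimated at 3500 nM, with an expected range from 1200 nM to 10000 nM.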

Compound 3, concentration for 50% growth inhibition: 5660 nM
The estimate for compound 3 lay 1.6-fold (0.21 log units) below the measured number, and the stated range covers the measured number.
By their numbers in this assay, from the lowest: compounds 1 and 3 (each within the scatter of the next); then compound 2.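

In this assay, the step to 4-ethylphenyl runs opposite to the earlier step to 4-hydroxy-2-methylphenyl, with a 4.4-fold lower number from compound 2 to compound 3 (0.64 log units; beyond the scatter), so the high number of compound 2 does not extend to every change at this carbon with a double bond to nitrogen. Adding a methyl to the 4-methylphenyl group of compound 1 gives a 1.9-fold higher number from compound 1 to compound 3 (0.29 log units; within the scatter), which lies within the scatter, so this one-carbon extension of the chain leaves the read-out unresolved and, of the three compounds, only compound 2 stands apart. No measurement at hand accounts for the gap between compound 2 and the other two compounds.

Since the hydroxy and the methyl arrive together in 4-hydroxy-2-methylphenyl, these compounds do not separate which of the two goes with the higher number of compound 2. Also open, going by these compounds, is how this position responds when the ethyl gives way to a longer chain such as butyl, to a methoxy group, or to an amine.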